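Removing one methoxy group from a hydroxychalcone enol

A few compounds are considered here, and "the series" means these few. Any claim that something is new, unique, unknown or untested is made for them only; others in the source may bear on it.

The series gathers four compounds built on the same core and tested in an in vitro assay on cells for inhibition of Amine oxidase [flavin-containing] A (Homo sapiens), read by Amplex Red, with a stated time of 15 min, tested at 100 uM; a higher number here means more inhibition at the concentration tested (going by the name of the read-out), a lower number less inhibition. Compound 1 `COc1ccc(/C=C/C=C/C(=O)c2ccccc2O)cc1` carries a single methoxy group and no enol hydroxyl on the linker; in this assay compound 1 gives 40%. Compound 2 `Cc1ccc(/C=C/C(O)=C/C(=O)c2ccccc2O)cc1` carries a methyl group and the enol hydroxyl; in this assay compound 2 is reported as "not active" (no number reported). Compound 3 `COc1ccc(/C=C/C(O)=C/C(=O)c2ccccc2O)cc1OC` carries two methoxy groups together with the enol hydroxyl; in this assay compound 3 is likewise reported as "not active" (no number reported). Going by the values given here, compound 3 thus stands without a single number, sharing that position with one further entry, compound 2, and the only numeric reading in the set belongs to compound 1.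

Compound 4 `COc1ccc(/C=C/C(O)=C/C(=O)c2ccccc2O)cc1` has not yet been measured. It differs from compound 3 in one place: hydrogen in place of methoxy on an aromatic carbon. Among the compounds with values here, no step between measured compounds is available, so the size of the change cannot be read from the data. Both measured carriers of the enol hydroxyl, compound 2 and compound 3, are reported as not active, while compound 1 lacks that hydroxyl, so compound 4 is expected to stay low in this assay, with an estimated inhibition of 15%, between 0% and 40%.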

Compound 4, a percentage reported as inhibition, at one concentration (the size of the read-out at that concentration, not a potency): "not active" (no number reported)
Nothing numeric was reported for compound 4, and the estimate cannot be compared.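

In this assay compound 3 and compound 4 are both reported as not active, with no number, so no step can be read between them. The compounds shown leave open whether hydrogen in place of methoxy changes inhibition at all. No measured evidence bears on this result.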